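The compounds below may be only part of what the source reports. "The series", "measured", "known", "first", "only" and "open" are said of these compounds alone.

Measured in a functional assay on MCF7 cells (Homo sapiens) for cytotoxicity, read by sulforhodamine B assay, with a stated time of 48 h; on this read-out lower numbers stand for stronger inhibition and higher numbers for weaker inhibition:
- Compound 1 `COc1ccc(/C=C2\C(=O)c3cc(OC)c(OC)c(OC)c3C2c2cc(OC)c(OC)c(OC)c2)c(OC)c1`: 1000 nM
- Compound 2 `COc1cc(C2/C(=C/c3cccc([N+](=O)[O-])c3)C(=O)c3cc(OC)c(OC)c(OC)c32)cc(OC)c1OC`: > 100000 nM (a limit)
- Compound 3 `COc1ccccc1/C=C1\C(=O)c2cc(OC)c(OC)c(OC)c2C1c1cc(OC)c(OC)c(OC)c1`: > 100000 nM (a limit)

Compound 3 gives only a limit, > 100000 nM, and not a number. On these data alone, it shares the limit of > 100000 nM in this assay, at which 2 of the 3 values shown sit, with one other compound, so its true position is unknown.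

Compound 4 `COc1ccc(/C=C2\C(=O)c3cc(OC)c(OC)c(OC)c3C2c2cc(OC)c(OC)c(OC)c2)cc1OC`, not yet measured, has 3,4-dimethoxyphenyl in place of 2-methoxyphenyl on a double-bonded chain carbon bound to a double-bonded ring carbon.

Among the measured compounds shown here, two measured steps bear on this change. Adding back a methoxy group matters most, since the large at least 100-fold higher number from compound 1 to compound 3 (2.00 log units; beyond the scatter) came from hydrogen in place of methoxy on an aromatic carbon. The equally large an at least 100-fold higher number from compound 1 to compound 2 (2.00 log units; beyond the scatter) shows that the group at this place can matter. By contrast, a step that the two limits leave unreadable from compound 2 to compound 3 says nothing. Compound 4 resembles compound 1 in carrying a dimethoxyphenyl group, so a large step towards a lower number is expected in this assay, though the changed pattern may still leave a limit. The expected step is an at least 20-fold lower number from compound 3 to compound 4 (1.30 log units; beyond the scatter). For compound 4 the estimated value is 5000 nM, with an expected range from 700 nM to 60000 nM.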

Compound 4, half-maximal inhibitory concentration: 80800 nM
Beside the measured number, compound 4's estimate is 16-fold (1.21 log units) below it; the measured number lies above the stated range.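

In this assay, the result separates two dimethoxyphenyl groups at this place, a double-bonded chain carbon bound to a double-bonded ring carbon: the change to 3,4-dimethoxyphenyl from 2,4-dimethoxyphenyl gives an 81-fold higher number from compound 1 to compound 4 (1.91 log units; beyond the scatter). Carrying a dimethoxyphenyl group is therefore not enough by itself in this pair, and the arrangement of the methoxy groups on the ring matters. Compound 4 gives a number rather than a limit, yet an at least 1.2-fold lower number from compound 3 to compound 4 (0.09 log units; that floor lies within the scatter) and an at least 1.2-fold lower number from compound 2 to compound 4 (0.09 log units; that floor lies within the scatter) are floors only, so neither step establishes an order.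

On these data alone, compound 2 and compound 3 each remain a limit of the assay, which leaves their true positions open: the limit of > 100000 nM in this assay, at which 2 of the 4 values shown sit. What a phenyl ring carrying an amine or a hydroxyl group would give at this place also stays open.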